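This account rests on a few compounds, and the source may have more. Where it says the series, first, only, none or still open, it means among the compounds named here.

Measured so far:
compound 1 `CCCN(CC[C@H]1CC[C@H](NC(=O)/C=C/c2cccc(Cl)c2)CC1)[C@H]1CCc2nc(N)sc2C1`: 1.2 nM
compound 2 `CCCN(CC[C@H]1CC[C@H](NC(=O)c2cccc3ncccc23)CC1)[C@H]1CCc2nc(N)sc2C1`: 1.6 nM

Going by the values given here, in an assay on brain for displacement of a labelled ligand from D(3) dopamine receptor (Rattus norvegicus) (a higher number here means a weaker inhibitor, a lower number a stronger inhibitor), compound 1 holds the lower of the two numbers, with compound 2 as its only neighbour; the step of a 1.3-fold higher number from compound 1 to compound 2 (0.12 log units; within the scatter) stays within the scatter. Compound 3 `CCCN(CC[C@H]1CC[C@H](NS(=O)(=O)c2ccc(OC)cc2)CC1)[C@H]1CCc2nc(N)sc2C1` differs from compound 1 by (4-methoxyphenyl)sulfonyl in place of (2-(3-chlorophenyl)ethenyl)carbonyl on an amine nitrogen. Among the compounds with values here, the only measured step that bears on this, from compound 1 to compound 2, changed just the aryl part on the carbonyl and was flat; no measured step covers exchange of the carbonyl itself for a sulfonyl. A modest rise is therefore expected, a 4.2-fold higher number from compound 1 to compound 3 (0.62 log units; beyond the scatter), with wide uncertainty. Compound 3 is estimated at 5 nM, range 1.2 nM to 30 nM.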

Compound 3, inhibition constant: 0.78 nM
Compound 3: middle estimate off by 6.4-fold (0.81 log units), on the high side, and the stated range ends above it.
By their numbers in this assay, from the lowest: compounds 3, 1 and 2 (each within the scatter of the next, the first and the last beyond it).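

On the amine nitrogen, (4-methoxyphenyl)sulfonyl in place of (2-(3-chlorophenyl)ethenyl)carbonyl gives a 1.5-fold lower number from compound 1 to compound 3 (0.19 log units; within the scatter) in this assay. The position therefore accepts a sulfonyl link as well as a carbonyl, with the aryl part changed in the same step, which the carbonyl-only pair of compound 1 and compound 2 could not show. No measurement at hand offers an explanation for this result. The sulfonyl and the aryl part change together here, leaving their separate contributions open. Also open, on these data alone, is how a methylsulfonyl group or a simple acetyl group would read on this nitrogen.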